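Removing One Bromine From an Amide at the Limit

The source may report more compounds than this note shows. Statements on the series, on what has been measured and on what is new or still open speak of the compounds shown alone.

In an assay on isolated protein for inhibition of thiosulfate sulfurtransferase (Homo sapiens), with a stated time of 60 min, in the absence of a further agent (on this read-out higher numbers stand for weaker inhibition and lower numbers for stronger inhibition), compound 1, with structure `COc1ccc(Br)cc1C(=O)Nc1ccc(Sc2nc3ccccc3s2)cc1`, gives > 100000 nM, which is a limit of the assay rather than a number. Compound 2, `O=C(Nc1ccc(Sc2nc3ccccc3s2)cc1)c1ccccc1`, gives > 100000 nM in this assay, again a limit. Compound 3, `O=C(Nc1ccc(Sc2nc3ccccc3s2)cc1)c1cc(Br)cc(Br)c1O`, gives > 100000 nM in this assay, also a limit. All three thus sit at the limit of > 100000 nM in this assay, at which 3 of the 3 values shown sit, and the three steps between them, a step that the two limits leave unreadable from compound 1 to compound 2, a step that the two limits leave unreadable from compound 1 to compound 3 and a step that the two limits leave unreadable from compound 2 to compound 3, cannot be read in size. Compound 3 stands with the others at that limit, showing no measurable inhibition.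

Compound 4, `O=C(Nc1ccc(Sc2nc3ccccc3s2)cc1)c1cc(Br)ccc1O`, differs from compound 3 in one place: hydrogen in place of bromo on an aromatic carbon. Going by the values given here, none of the measured steps can say how large an effect the loss of one bromo has, since each of them runs from one limit to another. What they do show is that three amides on this shared core, carrying no, one or two bromo groups, all stay at the limit, so the expected step of a number no higher from compound 3 to compound 4 (the limit leaves the size open) is none beyond the scatter, and the most likely outcome is one more limit. Compound 4 is therefore expected to give about 100000 nM, with a range from 30000 nM to 300000 nM.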

Compound 4, half-maximal inhibitory concentration: > 100000 nM
Compound 4 gave a limit, no number (the forecaster's own chance of this, stated with the estimate: 85%); the middle value sits exactly at the limit.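

In this assay compound 4 gives > 100000 nM as a limit and not a number, so its steps from compound 1, compound 2 and compound 3 cannot be read in size. Left open is how much any of these changes, including the loss of one bromo, alters inhibition, since all four compounds share one result: the limit of > 100000 nM in this assay, at which 4 of the 4 values shown sit.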